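The source may hold more compounds than are shown below. What is called first, only, known or untested is meant among the compounds shown, and "the series" means these compounds.

Measured compounds:
- compound 3 `CC(=O)Oc1ccccc1C(=O)Nc1c(C#N)[n+]([O-])c2cc(F)c(F)cc2[n+]1[O-]`: 10500 nM
- compound 1 `CC(=O)Oc1ccccc1C(=O)Nc1c(C#N)[n+]([O-])c2ccccc2[n+]1[O-]`: "not determined" (no result reported)
- compound 2 `COc1ccc2c(c1)[n+]([O-])c(C#N)c(NC(=O)c1ccccc1OC(C)=O)[n+]2[O-]`: "not determined" (no result reported)

Among the compounds with values here, in an ADME assay on cells (Peritoneal macrophage cell, Mus musculus) for cytotoxicity, read by trypan blue exclusion, with a stated time of 48 h (on this read-out higher numbers stand for lower toxicity in this test and lower numbers for higher toxicity in this test), compound 3 gives the only number in the set; for compound 1 and compound 2 the entry reads as no result, so compound 3 stands alone and no step between measured compounds can be drawn.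

Compound 4 `CC(=O)Oc1ccccc1C(=O)Nc1c(C#N)[n+]([O-])c2cc(F)ccc2[n+]1[O-]` follows from compound 3 by hydrogen in place of fluoro on an aromatic carbon. With no measured step of this kind in the series, the expectation for this assay is a step no larger than the usual scatter, with no direction claimed. The estimated result for compound 4 in this assay is 12000 nM, within 5000 nM to 30000 nM, which means an expected step of a 1.1-fold higher number from compound 3 to compound 4 (0.06 log units; within the scatter).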

Compound 4, half-maximal cytotoxic concentration: 13600 nM
Compound 4: middle estimate off by 1.1-fold (0.05 log units), on the low side; measured number inside the range.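

In this assay, within the data shown here, hydrogen in place of fluoro on an aromatic carbon, ortho to a fluoro group, gives a 1.3-fold higher number from compound 3 to compound 4 (0.11 log units; within the scatter) and is the only readable step. At this position, the fluoro group is thus not needed to keep the number within the scatter of that of compound 3. Nothing available explains the result.

Going by these compounds, whether an amine or a carboxylic acid at this position would behave the same way stays open. So does the outcome of replacing the remaining fluoro group.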